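Chalcone series: fluoropyridyl in place of fluorophenyl

The compounds below may be only part of what the source reports. "The series", "measured", "known", "first", "only" and "open" are said of these compounds alone.

Measured so far in a functional assay on MCF7 cells (Homo sapiens) for antiproliferative activity, read by sulforhodamine B assay, with a stated time of 48 h; on this read-out higher numbers stand for weaker inhibition and lower numbers for stronger inhibition:
compound 1 `O=C(/C=C/c1ccccc1-c1ccc(F)cc1)c1cccc(O)c1` gives 9300 nM
compound 2 `O=C(/C=C/c1ccccc1-c1ccc(F)nc1)c1cccc(O)c1` gives 12000 nM
compound 3 `COc1cc(C(=O)/C=C/c2ccccc2-c2ccc(F)cc2)ccc1O` gives 5400 nM

The change from compound 1 to compound 2 is 6-fluoropyridin-3-yl in place of 4-fluorophenyl on an aromatic carbon. It gave a 1.3-fold higher number from compound 1 to compound 2 (0.11 log units; within the scatter). Compound 4 `COc1cc(C(=O)/C=C/c2ccccc2-c2ccc(F)nc2)ccc1O` carries the same change on the core of compound 3: 6-fluoropyridin-3-yl in place of 4-fluorophenyl on an aromatic carbon. The difference between the cores of compound 1 and compound 3 is not broken down here; their values in this assay lie within the scatter of each other, so the two cores look alike on this read-out. In this assay, going by the values given here, the expected step is a 1.3-fold higher number from compound 3 to compound 4 (0.11 log units; within the scatter), because the same change at the same place gave a 1.3-fold higher number from compound 1 to compound 2 (0.11 log units; within the scatter); with only one earlier instance, the range is kept wide. Compound 4 is thus estimated at 7000 nM, likely between 3500 nM and 14000 nM.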

Compound 4, half-maximal inhibitory concentration: 27000 nM
Beside the measured number, compound 4's estimate is 3.9-fold (0.59 log units) below it; measured number above the stated range.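

On the second core, 6-fluoropyridin-3-yl in place of 4-fluorophenyl gives a 5.0-fold higher number from compound 3 to compound 4 (0.70 log units; beyond the scatter) in this assay. The change does not carry over at a fixed size between these two cores: the same change on two cores in this assay, a 1.3-fold higher number (0.11 log units; within the scatter) from compound 1 to compound 2 and a 5.0-fold higher number (0.70 log units; beyond the scatter) from compound 3 to compound 4, 3.9-fold (0.59 log units) apart, beyond the scatter of two such steps With only two instances, this shows that the size of the step depends on the core here, but not which feature of the core is responsible, nor does it set a general rule for the series.

The compounds shown leave open how the same change behaves on a core with an amine or a carboxylic acid in place of the hydroxyl group. Also open, from the compounds shown here alone, is whether a 6-chloropyridin-3-yl group would follow the same course.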